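The source may report more compounds than this note shows. Statements on the series, on what has been measured and on what is new or still open speak of the compounds shown alone.

Measured in a functional assay on UO-31 cells (Homo sapiens) for inhibition, read by sulforhodamine B assay, with a stated time of 48 h; on this read-out lower numbers stand for stronger inhibition of growth and higher numbers for weaker inhibition of growth:
- compound 1 `O=C(Nc1cccc(-n2cc(-c3ccncc3)c(-c3ccc(Cl)c(O)c3)n2)c1)Nc1ccc(Cl)c(Cl)c1`: 1250 nM
- compound 2 `O=C(Nc1cccc(-n2cc(-c3ccncc3)c(-c3ccc(Cl)c(O)c3)n2)c1)Nc1cc(C(F)(F)F)cc(C(F)(F)F)c1`: 647 nM
- compound 3 `COc1cc(-c2nn(-c3cccc(NC(=O)Nc4cccc(C(F)(F)F)c4)c3)cc2-c2ccncc2)ccc1Cl`: 702 nM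

Compound 3 sits in the middle of the three numbers; compound 2 is its nearest neighbour and compound 1 its furthest, and both gaps lie within the scatter, so the three compounds are not separable on these data.

Compound 4 `O=C(Nc1cccc(-n2cc(-c3ccncc3)c(-c3ccc(Cl)c(O)c3)n2)c1)Nc1cccc(C(F)(F)F)c1` is not yet measured. It differs from compound 3 by one change, (hydrogen in place of methyl on an oxygen on an aromatic ring). Going by the values given here, no measured pair shows this change, so its effect is unknown here. Compounds 1 and 2 carry the hydroxy form and land within the scatter of compound 3, so no step beyond the scatter is expected in this assay, in either direction. Compound 4 is expected to give 650 nM, within 300 nM to 1500 nM, the step expected being a 1.1-fold lower number from compound 3 to compound 4 (0.03 log units; within the scatter).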

Compound 4, concentration for 50% growth inhibition: 1860 nM
The estimate for compound 4 lay 2.9-fold (0.46 log units) below the measured number; measured number outside the range, above it.
By their numbers in this assay, from the lowest: compounds 2, 3, 1 and 4 (each within the scatter of the next, the first and the last beyond it).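

In this assay, the first direct read of methoxy to hydroxy on the aromatic ring shows weaker growth inhibition with the hydroxy form, with a 2.6-fold higher number from compound 3 to compound 4 (0.42 log units; beyond the scatter). Within the hydroxy form, the group on the amide-type nitrogen also matters, though not for every change: hydrogen in place of trifluoromethyl gives a 2.9-fold higher number from compound 2 to compound 4 (0.46 log units; beyond the scatter), while 3-(trifluoromethyl)phenyl in place of 3,4-dichlorophenyl gives a 1.5-fold higher number from compound 1 to compound 4 (0.17 log units; within the scatter). Nothing available accounts for these steps.

Going by these compounds, whether the methoxy-to-hydroxy step holds with other groups on the amide-type nitrogen stays open. So does how an ethoxy group or an amine would compare at that ring position.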